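From 2-Fluorophenyl to 4-Fluorophenyl: Expecting Compound 4

The source may report more compounds than this note shows. Statements on the series, on what has been measured and on what is new or still open speak of the compounds shown alone.

Of the compounds shown here, three sharing one core have been tested in a toxicity assay on THP-1 cells (Homo sapiens) for inhibition (a higher number here means that more compound is tolerated, a lower number that less compound is tolerated), and none has given a number. Compound 1 (`Cn1c(-c2ccccc2F)cnc1NC(=O)c1ccc(F)cc1`) gives > 100000 nM, which is a limit of the assay. Compound 2 (`Cc1cccc(C(=O)Nc2ncc(-c3ccccc3)n2C)c1`) gives > 50000 nM, also a limit. Compound 3 (`COc1ccc(-c2cnc(NC(=O)c3ccno3)n2C)cc1`) gives > 100000 nM, again a limit. Compound 1 therefore stands at the limit of > 100000 nM in this assay, at which 2 of the 3 values shown sit.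

Compound 4 (`Cn1c(-c2ccc(F)cc2)cnc1NC(=O)c1ccc(F)cc1`) has the same atoms as compound 1, joined differently: 4-fluorophenyl replaces 2-fluorophenyl on an aromatic carbon of a five-membered aromatic ring with 2 nitrogen (4-fluorophenyl in place of 2-fluorophenyl on an aromatic carbon). Among the compounds with values here, no measured pair here differs in one place only, so no measured step can serve as a guide. In this assay, no change beyond the scatter is expected, in either direction, and the result may well be only a limit again. The estimated step of a number no higher from compound 1 to compound 4 (the limit leaves the size open) is accordingly expected to be small. For compound 4 the expected value is 100000 nM, within an estimated range of 50000 nM to 200000 nM.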

Compound 4, half-maximal cytotoxic concentration: > 100000 nM
Compound 4 was reported as a limit; the forecaster's own chance of this, stated with the estimate: 85%; the middle value sits exactly at the limit.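

In this assay compound 4 gives > 100000 nM, which is a limit. Compound 1 also stands at a limit, so the step between compound 1 and compound 4 cannot be read. The compounds shown leave open whether 4-fluorophenyl in place of 2-fluorophenyl changes the tolerated concentration at all.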